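A Bromobenzyl Ether Tested for Macrophage Cytotoxicity

The source may hold more compounds than are shown below. What is called first, only, known or untested is meant among the compounds shown, and "the series" means these compounds.

Compound 1 `COc1ccc(C(O)C2OC(=O)c3c(OC)cc(OC)cc32)cc1` was examined in an ADME assay on RAW264.7 cells (Mus musculus) for cytotoxicity, read by MTT assay, with a stated time of 24 h, in the absence of a further agent; on this read-out lower numbers stand for stronger inhibition and higher numbers for weaker inhibition. In this assay compound 1 gives > 40000 nM, which is a limit of the assay rather than a number. Compound 2 `CCCOc1ccc(C(O)C2OC(=O)c3c(OC)cc(OC)cc32)cc1` carries an ethyl in place of hydrogen on a saturated chain carbon bound to an oxygen on an aromatic ring, and in this assay compound 2 gives > 40000 nM, again a limit. Compound 3 `COCCCCOc1ccc(C(O)C2OC(=O)c3c(OC)cc(OC)cc32)cc1` gives > 40000 nM in this assay, also a limit. The steps a step that the two limits leave unreadable from compound 1 to compound 2, a step that the two limits leave unreadable from compound 1 to compound 3 and a step that the two limits leave unreadable from compound 2 to compound 3 are therefore unreadable, since (the limit of > 40000 nM in this assay, at which 3 of the 3 values shown sit).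

Compound 4 `COc1cc(OC)c2c(c1)C(C(O)c1ccc(OCc3ccc(Br)cc3)cc1)OC2=O` differs from compound 1 by 4-bromophenyl in place of hydrogen on a saturated chain carbon bound to an oxygen on an aromatic ring. For the measured compounds named here, none of the measured steps yields a readable size, so they give no direction for this change; they show only that the chain on the oxygen can be lengthened in several ways while every value stays at the limit. The 4-bromophenyl is larger than any group entered among the measured compounds, so some cytotoxicity in this assay cannot be excluded. Compound 4 is nevertheless expected to sit at 40000 nM, with a range from 15000 nM to 100000 nM. The step expected from compound 1 to compound 4, a number no higher from compound 1 to compound 4 (the limit leaves the size open), is estimated to be none beyond the scatter.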

Compound 4, half-maximal inhibitory concentration: > 40000 nM
Compound 4 gave a limit, no number; the forecaster's own chance of this, stated with the estimate: 60%; the middle value sits exactly at the limit.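

Compound 4 also gives only a limit in this assay, so its steps from compound 1, compound 2 and compound 3 cannot be read: the limit of > 40000 nM in this assay, at which 4 of the 4 values shown sit.

The compounds shown leave open where the half-maximal inhibitory concentration of compound 1, compound 2, compound 3 or compound 4 actually lies, and whether any of these groups changes it.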